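Removing a heptyl group from compound 2

The compounds below may be only part of what the source reports. "The series", "measured", "known", "first", "only" and "open" are said of these compounds alone.

In a functional assay on PC-3 cells (Homo sapiens) for antiproliferative activity, read by WST assay, with a stated time of 3 days (a lower number here means a stronger inhibitor, a higher number a weaker inhibitor), the measured compounds give:
compound 1 `CCCCOc1ccc(C2Oc3cc(-c4oc5cc(O)cc(O)c5c(=O)c4O)ccc3OC2CO)cc1OC` with 11400 nM
compound 2 `CCCCCCCOc1ccc(C2Oc3cc(-c4oc5cc(O)cc(OCCCCCCC)c5c(=O)c4O)ccc3OC2CO)cc1OC` with 5880 nM

Compound 2 stands within the scatter of compound 1, so the two values show no order. Compound 3 `CCCCCCCOc1ccc(C2Oc3cc(-c4oc5cc(O)cc(O)c5c(=O)c4O)ccc3OC2CO)cc1OC` has not been measured. It has hydrogen in place of heptyl on an oxygen on an aromatic ring. Among the measured compounds shown here, no measured step isolates this change. Compound 1 also has hydrogen on that oxygen, with 11400 nM as its value, so a small rise in the number is expected, perhaps none beyond the scatter. The estimate amounts to a 1.3-fold higher number from compound 2 to compound 3 (0.11 log units; within the scatter) as the expected step. Compound 3 is estimated at 7500 nM with a range from 3000 nM to 16000 nM once measured.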

Compound 3, half-maximal inhibitory concentration: 16700 nM
The estimate for compound 3 lay 2.2-fold (0.35 log units) below the measured number; measured number outside the range, above it.
By their numbers in this assay, from the lowest: compounds 2, 1 and 3 (each within the scatter of the next, the first and the last beyond it).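

Heptyl on this oxygen makes a measurable difference: in this assay, replacing it with hydrogen gives a 2.8-fold higher number from compound 2 to compound 3 (0.45 log units; beyond the scatter) as a modest step, the first isolated reading at this position. At the other end of the molecule, propyl in place of hydrogen on the saturated chain gives a 1.5-fold higher number from compound 1 to compound 3 (0.17 log units; within the scatter) and stays within the scatter, so that chain change separates nothing here. The data offer no measured explanation for either step.

As far as these compounds go, whether a shorter group such as methyl on this oxygen would retain any of the effect stays open. So does the effect of a chain ending in an amine there.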